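The source may hold more compounds than are shown below. What is called first, only, known or untested is meant among the compounds shown, and "the series" means these compounds.

Measured so far in a functional assay on MGC-803 cells (Homo sapiens) for inhibition, read by CCK-8 assay, with a stated time of 48 h; on this read-out lower numbers stand for stronger inhibition and higher numbers for weaker inhibition:
Compound 1 `COc1ccc(CN(C(=O)CSC(=S)N2CCCc3cc(C)ccc32)c2cc(OC)c(OC)c(OC)c2)cc1`: 6490 nM
Compound 2 `COc1cc(N(Cc2ccc(C)cc2)C(=O)CSC(=S)N2CCN(C(=O)OC(C)(C)C)CC2)cc(OC)c1OC`: 16700 nM

Compound 2, at 16700 nM, holds the higher of the two numbers and so is the weaker, with a gap to compound 1 that lies beyond the scatter. Compound 3 `COc1ccc(CN(C(=O)CSC(=S)N2CCN(C(=O)OC(C)(C)C)CC2)c2cc(OC)c(OC)c(OC)c2)cc1[N+](=O)[O-]` carries 4-methoxy-3-nitrophenyl in place of 4-methylphenyl on a saturated chain carbon bound to an amide-type nitrogen. Going by the values given here, no single-change step has been measured, so only a modest shift towards a lower number is expected in this assay. The estimated step is a 1.9-fold lower number from compound 2 to compound 3 (0.27 log units; within the scatter). For compound 3 the expected value is 9000 nM, with an estimated range of 3000 nM to 25000 nM.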

Compound 3, half-maximal inhibitory concentration: 880 nM
Compound 3: middle estimate off by 10-fold (1.01 log units), on the high side, and the stated range ends above it.
By their numbers in this assay, from the lowest: compound 3; then compound 1; then compound 2.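

In this assay, 4-methoxy-3-nitrophenyl in place of 4-methylphenyl on a saturated chain carbon bound to an amide-type nitrogen gives a 19-fold lower number from compound 2 to compound 3 (1.28 log units; beyond the scatter) in a single change, the first such pair available. This shows that the number is highly sensitive to the group at this position, with the rest of compound 2 unchanged in compound 3. No measurement at hand accounts for the step.

Going by these compounds, the methyl group is lost and the methoxy and nitro groups arrive together, so the share of each remains open. On these data alone, how an amine in place of the nitro group would fare also remains open.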